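Swapping 2-phenylethenyl for methyl on a carbonyl carbon

The source may hold more compounds than are shown below. What is called first, only, known or untested is meant among the compounds shown, and "the series" means these compounds.

Of the compounds shown here, three with a shared core have been measured in a functional assay on MCF7 cells (Homo sapiens) for antiproliferative activity, read by MTT assay, with a stated time of 48 h; on this read-out higher numbers stand for weaker inhibition and lower numbers for stronger inhibition. Compound 1 `CN(C)CCNc1cc2c(cn1)cc(NC(=O)c1ccc(N)cc1)c(=O)n2C` gives 55800 nM, compound 2 `COc1cccc(C(=O)Nc2cc3cnc(NCCN(C)C)cc3n(C)c2=O)c1` gives 43300 nM, and compound 3 `CN(C)CCNc1cc2c(cn1)cc(NC(=O)/C=C/c1ccccc1)c(=O)n2C` gives 27400 nM. Compound 3 stands clear of only one of the others: the numbers show a 2.0-fold lower number from compound 1 to compound 3 (0.31 log units; beyond the scatter), but also a 1.6-fold lower number from compound 2 to compound 3 (0.20 log units; within the scatter).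

Compound 4 `CC(=O)Nc1cc2cnc(NCCN(C)C)cc2n(C)c1=O` is still unmeasured. It carries methyl in place of 2-phenylethenyl on a carbonyl carbon. Among the compounds with values here, all the measured steps changed the group at this same carbonyl carbon, yet each one swapped a group holding a ring for another such group, so the data do not show what losing the ring does. The first of these steps, a 1.3-fold lower number from compound 1 to compound 2 (0.11 log units; within the scatter), stayed small, and the widest, a 2.0-fold lower number from compound 1 to compound 3 (0.31 log units; beyond the scatter), sets the scale. A step of similar size is therefore expected in this assay, towards a higher number, though with little certainty. The expected step is a 2.0-fold higher number from compound 3 to compound 4 (0.30 log units; within the scatter). Compound 4 is estimated at 55000 nM, within an expected range of 27000 nM to 110000 nM.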

Compound 4, half-maximal inhibitory concentration: > 100000 nM
Compound 4 ended at the assay's limit (the forecaster's own chance of this, stated with the estimate: 15%); middle value at least 1.8-fold (0.25 log units) from the limit.
By their numbers in this assay, from the lowest: compounds 3, 2 and 1 (each within the scatter of the next, the first and the last beyond it). At a limit, above all of these: compound 4.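

Compound 4 gives no number but a limit of the assay: the limit of > 100000 nM in this assay, at which 1 of the 4 values shown sits. Within the data shown here, this is the first change here that removes the ring altogether, with methyl entering at the carbonyl carbon, and it gives an at least 3.6-fold higher number from compound 3 to compound 4 (0.56 log units; beyond the scatter) and an at least 2.3-fold higher number from compound 2 to compound 4 (0.36 log units; beyond the scatter), so a ring-bearing group on this carbon goes with the lower numbers in compounds 3 and 2. Compound 1 goes against any such rule, even with its 4-aminophenyl group: an at least 1.7-fold higher number from compound 1 to compound 4 (0.25 log units; that floor lies within the scatter), so compound 1 cannot be separated from compound 4.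

As far as these compounds go, whether the ring itself matters or any larger group would serve stays open, and a cyclohexyl group or a plain butyl chain on this carbonyl carbon would help to tell these apart. How far compound 4 lies past its limit cannot be read.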